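Halogen swap at the benzyl ring: compound 3 to compound 4

The source may hold more compounds than are shown below. What is called first, only, known or untested is meant among the compounds shown, and "the series" means these compounds.

Measured so far:
compound 1 `CCc1ccccc1N(CC(=O)NCc1ccc(OC)c(OC)c1)S(=O)(=O)c1ccc(C)cc1` 282 nM
compound 2 `CCc1ccccc1N(CC(=O)NCc1cccc(OC)c1)S(=O)(=O)c1ccc(C)cc1` 138 nM
compound 3 `CCc1ccccc1N(CC(=O)NCc1cccc(Cl)c1)S(=O)(=O)c1ccc(C)cc1` 1410 nM

All three share one core and differ only in the aromatic ring attached to the saturated chain carbon bound to an amide-type nitrogen. In a functional assay on CHO-K1 cells for antagonist activity at prostaglandin E2 receptor EP1 subtype (Homo sapiens), read by FLIPR and calcium flux (on this read-out higher numbers stand for weaker inhibition and lower numbers for stronger inhibition), compound 3 gives the highest of the three numbers, so it is the weakest inhibitor here: a 5.0-fold higher number from compound 1 to compound 3 (0.70 log units; beyond the scatter) and a 10-fold higher number from compound 2 to compound 3 (1.01 log units; beyond the scatter), both beyond the scatter. Compound 4 `CCc1ccccc1N(CC(=O)NCc1ccc(Br)cc1)S(=O)(=O)c1ccc(C)cc1` differs from compound 3 by 4-bromophenyl in place of 3-chlorophenyl on a saturated chain carbon bound to an amide-type nitrogen.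

Among the measured compounds shown here, no measured step isolates this kind of change. The two steps leading to compound 3 both replace a methoxy-bearing ring with a chlorine-bearing one, and a 2.0-fold lower number from compound 1 to compound 2 (0.31 log units; beyond the scatter) concerns the loss of a methoxy. None of them compares one halogen with another or moves a group around the ring. Swapping one halogen for another therefore gives no clear signal, and a step within the scatter is expected: a 1.1-fold higher number from compound 3 to compound 4 (0.03 log units; within the scatter). Compound 4 is estimated at 1500 nM, between 500 nM and 4500 nM.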

Compound 4, inhibition constant: 22.9 nM
Compound 4: the middle estimate sits 66-fold (1.82 log units) above what was measured, and the stated range ends above it.
By their numbers in this assay, from the lowest: compound 4; then compound 2; then compound 1; then compound 3.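

In this assay, the aromatic ring on the saturated chain carbon bound to an amide-type nitrogen can change the number sharply even when a halogen-bearing ring replaces another halogen-bearing ring, with a 62-fold lower number from compound 3 to compound 4 (1.79 log units; beyond the scatter). The step to chloro had made a halogen look like a loss here, yet 4-bromophenyl also outperforms both methoxy-bearing rings, with a 6.0-fold lower number from compound 2 to compound 4 (0.78 log units; beyond the scatter) and a 12-fold lower number from compound 1 to compound 4 (1.09 log units; beyond the scatter). No measurement offered here explains this difference.

The halogen and its place on the ring change together from compound 3 to compound 4, so the compounds shown cannot separate the two contributions. They also leave open how a ring carrying a nitrile or a carboxylic acid would behave at this position.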